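This account rests on a few compounds, and the source may have more. Where it says the series, first, only, none or still open, it means among the compounds named here.

Measured compounds in a functional assay on Vero cells (Chlorocebus sabaeus) for cytotoxicity, read by MTT assay; on this read-out lower numbers stand for higher toxicity in this test and higher numbers for lower toxicity in this test:
- compound 1 `O=c1[nH]c(=O)n(COCCO)cc1[N+](=O)[O-]`: > 432000 nM
- compound 2 `Cc1cc(=O)[nH]c(=O)n1COCCO`: > 500000 nM
- compound 3 `Cc1c(I)c(=O)[nH]c(=O)n1COCCO`: > 306000 nM

Each of these three values is a limit of this assay, not a number. For compound 3 the reading is the limit (the limit of > 306000 nM in this assay, at which 1 of the 3 values shown sits). For compound 1 it is the limit (the limit of > 432000 nM in this assay, at which 1 of the 3 values shown sits). For compound 2 it is the limit (the limit of > 500000 nM in this assay, at which 1 of the 3 values shown sits). Compound 3 therefore stands nowhere readable among the three: all three sit at limits, and the step that the two limits leave unreadable from compound 2 to compound 3 cannot be sized, since both ends are limits.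

The next compound is compound 4 `Cc1c([N+](=O)[O-])c(=O)[nH]c(=O)n1COCCO`. Its difference from compound 3 is nitro in place of iodo on an aromatic carbon. Going by the values given here, the only measured step that bears on this change is the one from compound 2 to compound 3, and it is unreadable. Compound 1, which carries a nitro group on a core lacking the methyl, also sits at a limit. Among the compounds with values here, no measured step gives a readable size in either direction, so no step beyond the scatter is expected; the expectation is that compound 4 is again reported only as a limit.

Compound 4 is estimated at 500000 nM, within 200000 nM to 1500000 nM, which as a step means the expected step that the limit leaves unreadable from compound 3 to compound 4.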

Compound 4, half-maximal cytotoxic concentration: > 408000 nM
Compound 4 ended at the assay's limit (the forecaster's own chance of this, stated with the estimate: 85%); the middle value lies beyond the limit too.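

In this assay compound 4 also gives only a limit, and none of its steps from compound 1, compound 2 or compound 3 can be read. The compounds shown leave open whether nitro, iodo or methyl on the shared core changes the half-maximal cytotoxic concentration at all, and where any of the four compounds actually stands.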